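The source may hold more compounds than are shown below. What is called first, only, known or untested is meant among the compounds shown, and "the series" means these compounds.

Of the compounds shown here, three of a shared core have been measured in an assay on isolated protein for binding affinity to Leucine-rich repeat serine/threonine-protein kinase 2 variant G2019S (Homo sapiens), read by TR-FRET and LanthaScreen, with a stated time of 2 h; on this read-out higher numbers stand for weaker inhibition and lower numbers for stronger inhibition. Compound 1 `CN(C)c1c(C#N)c2c(N)ncnc2n1C` gives 259 nM, compound 2 `C[C@@H]1CCCN1c1[nH]c2ncnc(N)c2c1C#N` gives 14 nM, and compound 3 `Cn1c(N2CCCC2)c(C#N)c2c(N)ncnc21` gives 125 nM. Compound 3 therefore stands second highest of the three numbers: its nearest neighbour is compound 1, and the gap to compound 2 is the widest. Within the data shown here, the one step between two measured compounds that differ in a single place, a 2.1-fold lower number from compound 1 to compound 3 (0.32 log units; beyond the scatter), exchanges one amino substituent for another at the same aromatic carbon and was modest.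

Compound 4 `Cn1c(-n2cccc2)c(C#N)c2c(N)ncnc21` is not yet measured. It differs from compound 3 in one place: 1H-pyrrol-1-yl in place of pyrrolidin-1-yl on an aromatic carbon. Among the measured compounds shown here, the step from compound 1 to compound 3 bears on this change only loosely, since it swaps one non-aromatic amine for another, while here a non-aromatic ring gives way to an aromatic one of the same size; no measured pair covers that exchange. The expectation in this assay is thus a step no larger than the scatter, a 2.0-fold higher number from compound 3 to compound 4 (0.30 log units; within the scatter), and compound 4 is estimated at 250 nM, within 80 nM to 800 nM.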

Compound 4, inhibition constant: 1980 nM
Beside the measured number, compound 4's estimate is 7.9-fold (0.90 log units) below it, and the stated range ends below it.
By their numbers in this assay, from the lowest: compound 2; then compound 3; then compound 1; then compound 4.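

On the aromatic carbon next to the ring nitrogen, this assay separates two five-membered rings with the same heavy-atom count: 1H-pyrrol-1-yl in place of pyrrolidin-1-yl gives a 16-fold higher number from compound 3 to compound 4 (1.20 log units; beyond the scatter), whereas the earlier exchange of one non-aromatic amine for another gave only a 2.1-fold lower number from compound 1 to compound 3 (0.32 log units; beyond the scatter). Replacing dimethylamino with 1H-pyrrol-1-yl also raises the number, with a 7.6-fold higher number from compound 1 to compound 4 (0.88 log units; beyond the scatter), so among these three compounds the aromatic ring stands apart from both non-aromatic amino groups. No supporting measurement accounts for this difference.

On these data alone, whether the loss extends to other aromatic rings at this carbon remains open, and an imidazol-1-yl or a phenyl group there would address it. Also open, as far as these compounds go, is whether the same exchange would have a similar effect on the core of compound 2, which differs from compound 3 in more than one place.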